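This account rests on a few compounds, and the source may have more. Where it says the series, first, only, none or still open, it means among the compounds named here.

In a functional assay on ECa-109 cells for inhibition, with ECa-109 cell line (Homo sapiens) as the target, read by sulforhodamine B assay (a lower number here means a stronger inhibitor, a higher number a weaker inhibitor), compound 1 `O=C1C(N2CCCC2)=CC(=O)c2c1nc1n2[C@H]2OC[C@@H](O)[C@H]2OC1` gives > 16000 nM, which is a limit of the assay and not a number. Compound 2 `O=C1C(NC2CCCCC2)=CC(=O)c2c1nc1n2[C@H]2OC[C@@H](O)[C@H]2OC1` gives > 16000 nM, again only a limit. Among the measured compounds shown here, no number therefore fixes where compound 2 stands, and the one other value available offers no firmer reference.

Compound 3 `CCCN(CCC)C1=CC(=O)c2c(nc3n2[C@H]2OC[C@@H](O)[C@H]2OC3)C1=O` carries dipropylamino in place of cyclohexylamino on a double-bonded ring carbon, on the shared core: dipropylamino in place of cyclohexylamino on a double-bonded ring carbon. The group thus loses its ring and its hydrogen-bond donor while keeping the same count of heavy atoms.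

For the measured compounds named here, the only measured step that bears on this change is a step that the two limits leave unreadable from compound 1 to compound 2, which also exchanges the amino group at this place. Its size cannot be read, so it gives neither a size nor a direction for the new change. No step beyond the scatter is therefore expected in this assay, and the expected step is a number no higher from compound 2 to compound 3 (the limit leaves the size open). For compound 3 the estimated value is 16000 nM, with an expected range from 6000 nM to 40000 nM. A report of only a limit is considered the likelier outcome.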

Compound 3, half-maximal inhibitory concentration: > 16000 nM
Compound 3 was reported as a limit; the forecaster's own chance of this, stated with the estimate: 70%; the middle value sits exactly at the limit.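

Among the compounds shown here, compound 3, like compound 1 and compound 2, is reported only as a limit, so no step between these three compounds can be read in this assay: the limit of > 16000 nM in this assay, at which 3 of the 3 values shown sit. The compounds shown leave open whether pyrrolidin-1-yl, cyclohexylamino and dipropylamino on the shared core differ at all in this assay.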